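Aryl versus pentyl alkynyl cytidine analogues in HeLa cytotoxicity

The compounds below may be only part of what the source reports. "The series", "measured", "known", "first", "only" and "open" are said of these compounds alone.

Measured so far:
compound 1 `CCCCCC#Cc1cn([C@@H]2O[C@H](CO)[C@@H](O)[C@H](O)[C@H]2O)c(=O)nc1N` — >= 250000 nM
compound 2 `CCCCCc1ccc(C#Cc2cn([C@@H]3O[C@H](CO)[C@@H](O)[C@H](O)[C@H]3O)c(=O)nc2O)cc1` — 31000 nM

In a functional assay on HeLa cells (Homo sapiens) for cytotoxicity, with a stated time of 72 h (on this read-out higher numbers stand for weaker inhibition and lower numbers for stronger inhibition), compound 1 gives >= 250000 nM, which is a limit of the assay and not a number. Compound 1 therefore stands at the edge of the measured range, (the limit of >= 250000 nM in this assay, at which 1 of the 2 values shown sits). In this assay, among the compounds with values here, compound 2 gives 31000 nM; compound 2 differs from compound 1 in more than one place, so the two values show only that an aryl-alkynyl member of the series does return a number.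

Compound 3 `CC(C)(C)c1ccc(C#Cc2cn([C@@H]3O[C@H](CO)[C@@H](O)[C@H](O)[C@H]3O)c(=O)nc2N)cc1` is not yet measured. It differs from compound 1 by 4-(tert-butyl)phenyl in place of pentyl on a triple-bonded carbon. Within the data shown here, since compound 1 offers only a limit, no measured step fixes the size of this change. The expected step of an at least 4.1-fold lower number from compound 1 to compound 3 (0.61 log units; beyond the scatter) points toward stronger inhibition, resting on the number seen for compound 2. Compound 3 is expected to give about 60000 nM, within 15000 nM to 250000 nM.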

Compound 3, half-maximal inhibitory concentration: 140000 nM
Compound 3: middle estimate off by 2.3-fold (0.37 log units), on the low side, within the range that was stated.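

In this assay, 4-(tert-butyl)phenyl in place of pentyl on a triple-bonded carbon gives an at least 1.7-fold lower number from compound 1 to compound 3 (0.25 log units; that floor lies within the scatter), the only one-place change shown at this position, and compound 3 stands at 140000 nM. Compound 1 gives >= 250000 nM, which is a limit of the assay and not a number. The step is therefore a floor, and its true size stays unfixed because compound 1 stands at the edge of the range: the limit of >= 250000 nM in this assay, at which 1 of the 3 values shown sits.

Open, on these data alone, is whether a plain phenyl or a longer chain such as octyl on the triple-bonded carbon would read like compound 3 or like compound 1. Also open, as far as these compounds go, is what a carboxylic acid or an amine on the aryl group would do to the read-out.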